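The source may hold more compounds than are shown below. What is called first, only, known or untested is meant among the compounds shown, and "the series" means these compounds.

In a functional assay on MC-38 cells (Mus musculus) for antiproliferative activity, read by colorimetric assay and MTT assay (a lower number here means a stronger inhibitor, a higher number a weaker inhibitor), compound 2 (`COc1ccc(S(=O)(=O)Nc2cccc3cc(O)[nH]c23)cc1`) gives 0.22 ug/mL, the lowest of three numbers, ahead of compound 1 (`COc1ccc(S(=O)(=O)Nc2cccc3cc[nH]c23)cc1`) at 1.5 ug/mL and compound 3 (`O=[N+]([O-])c1ccc(S(=O)(=O)Nc2cccc3cc(Cl)[nH]c23)cc1`) at 19 ug/mL. Compound 4 (`Nc1ccc(S(=O)(=O)Nc2cccc3cc(O)[nH]c23)cc1`) departs from compound 2 by one change: amino in place of methoxy on an aromatic carbon. Among the measured compounds shown here, the only measured step, a 6.8-fold lower number from compound 1 to compound 2 (0.83 log units; beyond the scatter), concerns hydroxy at another place, so it does not gauge this swap. Compound 3 carries neither group and differs in more than one place, so it gives no measure either. For the measured compounds named here, with no direct precedent, no shift beyond the scatter is expected, and the estimate means a 1.4-fold higher number from compound 2 to compound 4 (0.13 log units; within the scatter). For compound 4 the expected value is 0.3 ug/mL, with an estimated range of 0.08 ug/mL to 1.2 ug/mL.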

Compound 4, half-maximal inhibitory concentration: 1.8 ug/mL
For compound 4 the middle estimate is 6.0-fold (0.78 log units) below the measured one; the whole stated range lies below it.
By their numbers in this assay, from the lowest: compound 2; then compounds 1 and 4 (each within the scatter of the next); then compound 3.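

Placing amino in place of methoxy on the six-membered aromatic ring of carbon only, para to a large group, is not a neutral change in this assay and gives an 8.2-fold higher number from compound 2 to compound 4 (0.91 log units; beyond the scatter). Among the compounds shown here, this is the first direct sign that this position affects the number, and here methoxy goes with the lower number of the pair. No measurement shown explains the shift. Going by these compounds, whether a dimethylamino group or an ethoxy group at this position would keep the number low stays open. So does whether the same swap would have a similar effect on the core of compound 1.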